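4-bromophenyl for 3-methylphenyl on the aromatic nitrogen

A few compounds are considered here, and "the series" means these few. Any claim that something is new, unique, unknown or untested is made for them only; others in the source may bear on it.

In a functional assay on MDA-MB-468 cells (Homo sapiens) for antiproliferative activity, read by MTT assay, with a stated time of 72 h (on this read-out lower numbers stand for stronger inhibition and higher numbers for weaker inhibition), compound 1 (`CCCCn1ccnc1-c1cc(OC)c(OC)c(OC)c1`) gives a measured value (44100 nM). Compound 2 (`COc1cc(-c2nccn2Cc2ccccc2)cc(OC)c1OC`) reaches only a limit of the assay (> 100000 nM). For the measured compounds named here, compound 3 (`COc1cc(-c2nccn2-c2cccc(C)c2)cc(OC)c1OC`) gives a measured value (22600 nM) that stands level with the one number beside it, within the scatter of compound 1.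

Compound 4 (`COc1cc(-c2nccn2-c2ccc(Br)cc2)cc(OC)c1OC`) changes one place: 4-bromophenyl in place of 3-methylphenyl on an aromatic nitrogen. This is 4-bromophenyl in place of 3-methylphenyl on an aromatic nitrogen.

Three measured steps change the same nitrogen substituent. One lies within the scatter (a 2.0-fold lower number from compound 1 to compound 3 (0.29 log units; within the scatter)), and two lie beyond it (an at least 4.4-fold lower number from compound 2 to compound 3 (0.64 log units; beyond the scatter) and an at least 2.2-fold higher number from compound 1 to compound 2 (0.35 log units; beyond the scatter)). Each of these changes the type of substituent, and none exchanges one substituted phenyl for another, so the data give no direct size for this change. No shift beyond the scatter is therefore expected, and the estimated step is small (a 1.3-fold lower number from compound 3 to compound 4 (0.10 log units; within the scatter)). For compound 4 the expected value is 18000 nM (estimated range 4000 nM to 70000 nM).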

Compound 4, half-maximal inhibitory concentration: 2700 nM
Compound 4: the middle estimate sits 6.7-fold (0.82 log units) above what was measured; the measured number lies below the stated range.
By their numbers in this assay, from the lowest: compound 4; then compounds 3 and 1 (each within the scatter of the next). At a limit, above all of these: compound 2.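

An exchange of one substituted phenyl for another on the aromatic nitrogen is not neutral in this assay and gives an 8.4-fold lower number from compound 3 to compound 4 (0.92 log units; beyond the scatter) so this position responds to what the phenyl carries and not only to the type of substituent. Against butyl, 4-bromophenyl gives a 16-fold lower number from compound 1 to compound 4 (1.21 log units; beyond the scatter) whereas 3-methylphenyl gives only a 2.0-fold lower number from compound 1 to compound 3 (0.29 log units; within the scatter) and so a phenyl on this nitrogen does not by itself set a compound apart from the chain. Against benzyl the step is only a bound, an at least 37-fold lower number from compound 2 to compound 4 (1.56 log units; beyond the scatter) being read from a value that is a limit of the assay: the limit of > 100000 nM in this assay, at which 1 of the 4 values shown sits.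

The identity of the substituent and its place on the phenyl change together in this step, and the compounds shown do not separate the two. Going by these compounds, how a chlorine, a methoxy group or an amine on that phenyl would read remains open.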